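One Aryl Swap at the Alkyne of Compound 2

The source may report more compounds than this note shows. Statements on the series, on what has been measured and on what is new or still open speak of the compounds shown alone.

Within the data shown here, compound 2 `Cc1nc(C#Cc2ccc(C(=O)N[C@H](C)C(C)(C)O)nc2)cs1` holds the lower of the two numbers measured so far in a functional assay on HEK293 cells for positive allosteric modulation of metabotropic glutamate receptor 5 (Rattus norvegicus), read by fluorescence and calcium flux (on this read-out lower numbers stand for smaller maximal responses and higher numbers for larger maximal responses), where compound 2 gives 66.6%. Among the measured compounds shown here, its only measured neighbour is compound 1 `Cc1cccc(C#Cc2ccc(C(=O)N[C@H](C)C(C)(C)O)nc2)c1`, which in this assay gives 68.6%; the step of a number 2 percentage points lower from compound 1 to compound 2 (within the scatter) lies within the scatter, so the two compounds cannot be ordered against each other. Compound 3 `C[C@@H](NC(=O)c1ccc(C#Cc2ncccc2F)cn1)C(C)(C)O` departs from compound 2 in a single place: 3-fluoropyridin-2-yl in place of 2-methyl-1,3-thiazol-4-yl on a triple-bonded carbon. For the measured compounds named here, the one measured step that touches this position is a number 2 percentage points lower from compound 1 to compound 2 (within the scatter), in which a six-membered aromatic ring gave way to a five-membered one without moving the maximal response beyond the scatter. Returning to a six-membered aromatic ring, now carrying one nitrogen and one fluorine, is the only change on hand to judge from, and the precedent is flat. Compound 3 is therefore expected to reach about 67% in this assay, with a likely range from 50% to 84%. The expected step of a number 0.4 percentage points higher from compound 2 to compound 3 (within the scatter) is estimated to stay within the usual scatter.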

Compound 3, largest response reached (reported as efficacy), in percent of the reference or control that the assay uses: 60.6%
Estimate against measurement, compound 3: 6.4 percentage points above, within the range that was stated.
By their numbers in this assay, from the lowest: compounds 3, 2 and 1 (each within the scatter of the next).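

With compound 3, a third kind of aromatic ring stands on the triple-bonded carbon, and this assay still does not separate the groups: the swap to 3-fluoropyridin-2-yl gives a number 6 percentage points lower from compound 2 to compound 3 (within the scatter), and the comparison with the 3-methylphenyl group gives a number 8 percentage points lower from compound 1 to compound 3 (within the scatter). Among these compounds, the earlier pair showed only that a five-membered aromatic ring could replace a six-membered one within the scatter; these steps add a six-membered ring with a hetero atom and a fluorine substituent, and both also stay within the scatter, so none of the three groups can be ranked against the others on maximal response. No evidence available here bears on this result.

All three groups on the triple-bonded carbon are aromatic rings, which leaves open whether a saturated ring such as cyclohexyl, or a ring carrying an amine or a carboxylic acid, would keep the maximal response within the same scatter. The compounds shown also share the same hydroxyl-bearing amide side chain, so they do not tell how a longer chain or a different group in that place would read alongside any of these aromatic rings.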